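A Nitro Group Enters a Series Without Readable Cytotoxicity

The source may report more compounds than this note shows. Statements on the series, on what has been measured and on what is new or still open speak of the compounds shown alone.

The compounds share the core shown by compound 1, `c1ccc(Cn2cncc2CNc2cccc(-c3ccccc3)c2)cc1`. In a toxicity assay on NIH3T3 cells (Mus musculus) for cytotoxicity, read by resazurin assay (on this read-out lower numbers stand for an effect already at smaller amounts and higher numbers for an effect only at larger amounts of compound), compound 1 gives > 750 nM, which is a limit of the assay and not a number. Compound 2, `Cc1cccc(-c2cccc(NCc3cncn3Cc3ccccc3)c2)c1`, gives in this assay > 1000 nM, again a limit. Compound 3, `CC(C)c1cccc(NCc2cncn2Cc2ccccc2)c1`, gives in this assay > 1000 nM, a limit as well. The three measured steps, a step that the two limits leave unreadable from compound 1 to compound 2, a step that the two limits leave unreadable from compound 1 to compound 3 and a step that the two limits leave unreadable from compound 2 to compound 3, are of unreadable size because the limit of > 1000 nM in this assay, at which 2 of the 3 values shown sit, and the limit of > 750 nM in this assay, at which 1 of the 3 values shown sits, leave no number to compare.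

Compound 4, `O=[N+]([O-])c1ccc(Cn2cncc2CNc2cccc(-c3ccccc3)c2)cc1`, differs from compound 1 in one place: nitro in place of hydrogen on an aromatic carbon. Among the measured compounds shown here, none of the measured steps involves a nitro group, and none of them has a readable size, so there is nothing among the measured compounds to set a size or a direction for the step from compound 1 to compound 4 in this assay; the only guide is that every value shown sits at a limit. The step is expected to be a step that the limit leaves unreadable from compound 1 to compound 4, with compound 4 expected to remain at a limit as well. Compound 4 is therefore estimated to give about 2000 nM in this assay, between 700 nM and 6000 nM.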

Compound 4, half-maximal effective concentration: 10000 nM
Estimate against measurement, compound 4: 5.0-fold (0.70 log units) below; the measured number lies above the stated range.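

In this assay, among the compounds shown here, compound 4 gives a measured number while compound 1 stays at a limit, so the comparison between compound 1 and compound 4 yields no new step of readable size. The compounds shown leave open whether nitro in place of hydrogen on an aromatic carbon changes the read-out of compound 1 at all, and in which direction.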